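The compounds below may be only part of what the source reports. "The series", "measured", "known", "first", "only" and "open" are said of these compounds alone.

Among the compounds with values here, compound 1 `COc1ccc(/C=C/C(=O)c2ccccc2-c2ccc(F)cc2)cc1` gives 53 nM in a functional assay on CNE-2 cells (Homo sapiens) for antiproliferative activity, read by sulforhodamine B assay, with a stated time of 48 h (on this read-out higher numbers stand for weaker inhibition and lower numbers for stronger inhibition), the lowest of the three numbers measured so far, though its neighbours sit close. Compound 2 `COc1ccc(/C=C/C(=O)c2ccccc2-c2ccc(F)cc2)cc1OC` gives 81 nM and compound 3 `COc1ccc(/C=C/C(=O)c2ccccc2-c2ccc(F)cc2)cc1O` gives 87 nM; the steps of a 1.5-fold higher number from compound 1 to compound 2 (0.18 log units; within the scatter), a 1.6-fold higher number from compound 1 to compound 3 (0.22 log units; within the scatter) and a 1.1-fold higher number from compound 2 to compound 3 (0.03 log units; within the scatter) all stay within the scatter, so these three compounds cannot be told apart. Compound 4 `CN(C)c1ccc(/C=C/C(=O)c2ccccc2-c2ccc(F)cc2)cc1` differs from compound 1 by dimethylamino in place of methoxy on an aromatic carbon. Within the data shown here, no measured step replaces the methoxy; each only adds a hydroxy or methoxy while the original methoxy stays, so the measured steps bear on the new change only loosely. With nothing pointing to a shift, compound 4 is expected to stay near compound 1, the estimated step being a 1.2-fold lower number from compound 1 to compound 4 (0.07 log units; within the scatter). Compound 4 is thus estimated at 45 nM, between 15 nM and 140 nM.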

Compound 4, half-maximal inhibitory concentration: 30 nM
The estimate for compound 4 lay 1.5-fold (0.18 log units) above the measured number; the measured number falls inside the stated range.
By their numbers in this assay, from the lowest: compounds 4, 1, 2 and 3 (each within the scatter of the next, the first and the last beyond it).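

Within the data shown here, this is the first change that replaces the methoxy instead of adding a group beside it. In this assay, dimethylamino in place of methoxy gives a 1.8-fold lower number from compound 1 to compound 4 (0.25 log units; within the scatter), so the two groups cannot be told apart at this position, para to a large group. Nothing measured here explains how this swap acts on the cells.

The compounds shown leave open whether an unsubstituted amine, a longer chain on the nitrogen or a carboxylic acid at this position would give a clearly different number.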